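From 3-hydroxyphenyl to 3-chloro-4-hydroxyphenyl on a shared core

The source may hold more compounds than are shown below. What is called first, only, known or untested is meant among the compounds shown, and "the series" means these compounds.

Compound 1 `COc1ccc(/C=C2\CCC/C(=C\c3ccc(Br)cc3)C2=O)cc1OC` gives 4300 nM
Compound 2 `COc1ccccc1/C=C1\CCC/C(=C\c2ccc(OC)c(OC)c2)C1=O` gives 8100 nM
Compound 3 `COc1ccc(/C=C2\CCC/C(=C\c3cccc(O)c3)C2=O)cc1OC` gives 1700 nM

In a functional assay on HT-1080 cells (Homo sapiens) for cytotoxicity, read by MTT assay, with a stated time of 72 h (on this read-out higher numbers stand for weaker inhibition and lower numbers for stronger inhibition), compound 3 stands lowest of the three at 1700 nM and the other two lie above it. Compound 4 `COc1ccc(/C=C2\CCC/C(=C\c3ccc(O)c(Cl)c3)C2=O)cc1OC` carries 3-chloro-4-hydroxyphenyl in place of 3-hydroxyphenyl on a double-bonded chain carbon bound to a double-bonded ring carbon. All measured steps fall at this same place. They are a 2.5-fold lower number from compound 1 to compound 3 (0.40 log units; beyond the scatter) and a 4.8-fold lower number from compound 2 to compound 3 (0.68 log units; beyond the scatter) and also a 1.9-fold higher number from compound 1 to compound 2 (0.28 log units; within the scatter) at this place. The largest of them is modest. For the measured compounds named here, no measured pair isolates the new change, and no measured compound holds chlorine. Compound 1 with its 4-bromophenyl at 4300 nM lies above compound 3, which offers only a weak hint of a higher number. No step beyond the scatter is expected in this assay and the expected step is a 1.3-fold higher number from compound 3 to compound 4 (0.11 log units; within the scatter) at most modestly upward. The estimate for compound 4 is 2200 nM with an expected range (900 nM to 5000 nM).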

Compound 4, half-maximal inhibitory concentration: 7600 nM
Compound 4: the middle estimate sits 3.5-fold (0.54 log units) below what was measured; measured number outside the range, above it.
By their numbers in this assay, from the lowest: compound 3; then compounds 1, 4 and 2 (each within the scatter of the next).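

In this assay the place on a double-bonded chain carbon bound to a double-bonded ring carbon tolerates this change poorly: 3-chloro-4-hydroxyphenyl in place of 3-hydroxyphenyl gives a 4.5-fold higher number from compound 3 to compound 4 (0.65 log units; beyond the scatter) and so loses the lowest number of the series, although both groups hold a hydroxy group and the same counts of hydrogen-bond donors and acceptors. A hydroxy group on this ring is thus not enough to set a compound apart, since a 1.1-fold lower number from compound 2 to compound 4 (0.03 log units; within the scatter) and a 1.8-fold higher number from compound 1 to compound 4 (0.25 log units; within the scatter) leave compound 4 level with the two compounds that carry none. Nothing available explains this step.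

The compounds shown leave open how much of the step belongs to the chlorine and how much to the rest of the change within 3-chloro-4-hydroxyphenyl. They also leave open how an amine or a carboxylic acid would fare in place of the hydroxy group at this place.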